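From Methylcarbamoyl to Benzyl on the Ring Nitrogen

The source may report more compounds than this note shows. Statements on the series, on what has been measured and on what is new or still open speak of the compounds shown alone.

Compound 1 `CNC(=O)Nc1c(C)c(C(OC(C)(C)C)C(=O)O)c(-c2ccc(C)c(C)c2)c(C)c1-c1ccc(C)c(C)c1` is one of three close relatives tested in an ADME assay on MT4 cells (Homo sapiens) for cytotoxicity, read by MTT assay, with a stated time of 4 days (on this read-out higher numbers stand for lower toxicity in this test and lower numbers for higher toxicity in this test), where compound 1 gives 20000 nM. Compound 2 `Cc1ccc(-c2c(C)c(-c3ccc(C)c(C)c3)c(C(OC(C)(C)C)C(=O)O)c(C)c2NS(C)(=O)=O)cc1C` gives 15000 nM and compound 3 `Cc1ccc(-c2c(C)c(-c3ccc(Cl)c(F)c3)c(C(OC(C)(C)C)C(=O)O)c(C)c2NS(C)(=O)=O)cc1C` gives 22000 nM; compound 1 thus stands second highest of the three, and all three numbers sit within the scatter of one another. Compound 4 `Cc1ccc(-c2c(C)c(-c3ccc(C)c(C)c3)c(C(OC(C)(C)C)C(=O)O)c(C)c2NCc2ccccc2)cc1C` differs from compound 1 in one place: benzyl in place of methylcarbamoyl on a nitrogen on an aromatic ring. Neither measured step tries this exact change. The step of a 1.3-fold lower number from compound 1 to compound 2 (0.12 log units; within the scatter) alters the same nitrogen, but to methylsulfonyl, and the step of a 1.5-fold higher number from compound 2 to compound 3 (0.17 log units; within the scatter) alters a different part of the molecule; both stayed within the scatter. Going by the values given here, these two steps are the only guide, and on that guide the expected step is a 1.1-fold lower number from compound 1 to compound 4 (0.05 log units; within the scatter), that is, nothing beyond the scatter in either direction. Compound 4 is therefore estimated to give 18000 nM in this assay, with a range from 8000 nM to 40000 nM.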

Compound 4, half-maximal cytotoxic concentration: 4000 nM
The estimate for compound 4 lay 4.5-fold (0.65 log units) above the measured number, and the stated range ends above it.
By their numbers in this assay, from the lowest: compound 4; then compounds 2, 1 and 3 (each within the scatter of the next).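

In this assay, benzyl in place of methylcarbamoyl on the nitrogen gives a 5.0-fold lower number from compound 1 to compound 4 (0.70 log units; beyond the scatter), and benzyl in place of methylsulfonyl gives a 3.8-fold lower number from compound 2 to compound 4 (0.57 log units; beyond the scatter). The earlier change at this nitrogen, a 1.3-fold lower number from compound 1 to compound 2 (0.12 log units; within the scatter), had suggested that the position made little difference, but these steps show that the group it carries can move the number towards higher toxicity in this test. No measurement shown explains why benzyl has this effect. On these data alone, it remains open whether the aromatic ring of benzyl matters, or whether a plain methyl or a longer chain such as 2-phenylethyl on the same nitrogen would give a number closer to that of compound 4 or that of compound 1. As far as these compounds go, it is also open whether benzyl would lower the number in the same way alongside the 4-chloro-3-fluorophenyl group of compound 3.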